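Aryl in Place of Benzyl on the Amide Nitrogen

A few compounds are considered here, and "the series" means these few. Any claim that something is new, unique, unknown or untested is made for them only; others in the source may bear on it.

Compound 1 `COc1ccccc1NC(=O)CN(c1cc(Cl)ccc1OC)S(=O)(=O)c1ccccc1` is measured in a functional assay on SH-SY5Y cells (Homo sapiens), read by MTT assay, with a stated time of 24 h (a higher number here means that more compound is needed for the effect, a lower number that less compound is needed), at 15500 nM. Compound 2 `COc1ccc(CNC(=O)CN(c2cc(Cl)ccc2OC)S(=O)(=O)c2ccccc2)cc1` reaches only the limit of this assay, > 20000 nM, so its true number is not known. The step of an at least 1.2-fold higher number from compound 1 to compound 2 (0.11 log units; that floor lies within the scatter) therefore carries a floor only, set by the limit of > 20000 nM in this assay, at which 1 of the 2 values shown sits. Within the data shown here, compound 3 `COc1cccc(NC(=O)CN(c2cc(Cl)ccc2OC)S(=O)(=O)c2ccccc2)c1` differs from compound 2 by 3-methoxyphenyl in place of 4-methoxybenzyl on an amide-type nitrogen; this partly undoes the change from compound 1 to compound 2, the single measured step that bears on it. Because an at least 1.2-fold higher number from compound 1 to compound 2 (0.11 log units; that floor lies within the scatter) was at most small, the expected step is an at least 1.1-fold lower number from compound 2 to compound 3 (0.04 log units; that floor lies within the scatter), back toward measurable territory. Compound 3 is estimated at 18000 nM, with a range from 8000 nM to 40000 nM.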

Compound 3, half-maximal effective concentration: 17600 nM
For compound 3 the middle estimate is 1.0-fold (0.01 log units) above the measured one; measured number inside the range.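

Exchanging 2-methoxyphenyl for 3-methoxyphenyl on the amide nitrogen gives a 1.1-fold higher number from compound 1 to compound 3 (0.06 log units; within the scatter), so these two aryl groups cannot be told apart at this position in this assay. The comparison with 4-methoxybenzyl gives an at least 1.1-fold lower number from compound 2 to compound 3 (0.05 log units; that floor lies within the scatter), which leaves any difference between the aryl and benzyl groups unsettled, since this step carries only a floor: the limit of > 20000 nM in this assay, at which 1 of the 3 values shown sits.

The compounds shown leave open how an unsubstituted phenyl or a 4-methoxyphenyl group would behave on this nitrogen. They also leave open whether an amine or a carboxylic acid in place of the methoxy group would move the number beyond the scatter.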